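Extending the acid-bearing chain: from compound 3 to compound 4

A few compounds are considered here, and "the series" means these few. Any claim that something is new, unique, unknown or untested is made for them only; others in the source may bear on it.

Compound 1 `CCCc1c(OCCCOc2c(C(C)=O)ccc(OCCCC(=O)O)c2CCC)ccc(C(C)=O)c1O`, compound 2 `CCCc1c(OCCOCCOc2c(C(C)=O)ccc(OCC(=O)O)c2CCC)ccc(C(C)=O)c1O` and compound 3 `CCCc1c(OCCOCCOc2c(C(C)=O)ccc(OCCCC(=O)O)c2CCC)ccc(C(C)=O)c1O` share one core and differ in their linker and acid chains. In a functional assay on ileum (Cavia porcellus) for inhibition of cysteinyl leukotriene receptor (Homo sapiens) (on this read-out higher numbers stand for weaker inhibition and lower numbers for stronger inhibition), compound 1 gives 200 nM, compound 2 gives 200 nM and compound 3 gives 100 nM, the lowest of the three numbers, with the values of compound 1 and compound 2 each within the scatter of it. Compound 4 `CCCc1c(OCCOCCOc2c(C(C)=O)ccc(OCCCCCC(=O)O)c2CCC)ccc(C(C)=O)c1O` carries 2-carboxyethyl in place of carboxy on a saturated chain carbon, three bonds along the chain from an oxygen on an aromatic ring. Within the data shown here, the one measured step of the same kind, a 2.0-fold lower number from compound 2 to compound 3 (0.30 log units; within the scatter), stayed within the scatter. Compound 4 is therefore expected to show no change at the digits printed from compound 3 to compound 4 (within the scatter) in this assay, no step beyond the scatter. Compound 4 is estimated at 100 nM, with a range from 40 nM to 250 nM.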

Compound 4, half-maximal inhibitory concentration: 200 nM
Compound 4: middle estimate off by 2.0-fold (0.30 log units), on the low side; the measured number falls inside the stated range.
By their numbers in this assay, from the lowest: compounds 3, 1, 2 and 4 (each within the scatter of the next).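

In this assay the change to 2-carboxyethyl at this position gives a 2.0-fold higher number from compound 3 to compound 4 (0.30 log units; within the scatter) and the wider change from carboxy to 4-carboxybutyl gives no change at the digits printed from compound 2 to compound 4 (within the scatter) and so, with the linker held constant, the three acid chains in compound 2, compound 3 and compound 4 all lie within the scatter of one another. Among these compounds, no step along this series of chain lengths rises beyond the scatter, even across its widest span. Nothing available bears on the reason for this result.

As far as these compounds go, whether a chain longer than 5-carboxypentyl, or an amide in place of the carboxylic acid, would stay within the scatter remains open.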